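Pyridin-4-yl for oxazolyl on a low-toxicity scaffold

The source may hold more compounds than are shown below. What is called first, only, known or untested is meant among the compounds shown, and "the series" means these compounds.

Measured compounds:
Compound 1 `O=c1n(Cc2cc3cnccc3n2CCCCO)c2cnccc2n1C1CC1`: > 100000 nM
Compound 2 `N#CCCCn1c(Cn2c(=O)n(-c3ncco3)c3ccncc32)cc2cc(Cl)ccc21`: > 50000 nM
Compound 3 `CS(=O)(=O)CCCn1c(Cn2c(=O)n(C3CC3)c3ccncc32)cc2cc(C(F)(F)F)ccc21`: > 50000 nM

In an ADME assay on HeLa cells (Homo sapiens) for cytotoxicity, read by ATP content, with a stated time of 3 days (on this read-out lower numbers stand for higher toxicity in this test and higher numbers for lower toxicity in this test), every value recorded so far is a limit of the test rather than a number. Compound 1 gives > 100000 nM, which is a limit (the limit of > 100000 nM in this assay, at which 1 of the 3 values shown sits). Compound 2 gives > 50000 nM, again a limit. Compound 3 gives > 50000 nM, the same limit (the limit of > 50000 nM in this assay, at which 2 of the 3 values shown sit). Going by the values given here, compound 2 therefore stands at a limit, and no measured step sets it apart from the other two.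

Compound 4 `N#CCCCn1c(Cn2c(=O)n(-c3ccncc3)c3ccncc32)cc2cc(Cl)ccc21` differs from compound 2 in one place: pyridin-4-yl in place of 1,3-oxazol-2-yl on an aromatic nitrogen. Among the compounds with values here, no step between measured compounds is available to size this change. The expected step that the limit leaves unreadable from compound 2 to compound 4 is none beyond the scatter, and compound 4 is expected to sit once more at a limit. Compound 4 is estimated at 80000 nM, within a range from 30000 nM to 200000 nM.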

Compound 4, half-maximal cytotoxic concentration: > 50000 nM
Compound 4: only a limit was reported; the forecaster's own chance of this, stated with the estimate: 80%; the middle value is on the limit's open side.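

In this assay, going by these compounds alone, compound 4 gives > 50000 nM, a limit, and compound 2 also stands at a limit, so no step between them can be read. The compounds shown leave open how pyridin-4-yl and 1,3-oxazol-2-yl compare here.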